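Dimethyl substitution on the anilide of a bis-benzylidene piperidinone

This account rests on a few compounds, and the source may have more. Where it says the series, first, only, none or still open, it means among the compounds named here.

Compound 1 `O=C(/C=C/C(=O)N1C/C(=C\c2ccccc2)C(=O)/C(=C/c2ccccc2)C1)Nc1ccccc1`: 1100 nM
Compound 2 `Cc1cccc(C)c1NC(=O)/C=C/C(=O)N1C/C(=C\c2ccc([N+](=O)[O-])cc2)C(=O)/C(=C/c2ccc([N+](=O)[O-])cc2)C1`: 230 nM

In a functional assay on CCRF-CEM cells (Homo sapiens) for cytotoxicity (a lower number here means a stronger inhibitor, a higher number a weaker inhibitor), compound 1 gives 1100 nM, the higher of the two numbers recorded. Compound 2 returns 230 nM, a lower number that lies beyond the scatter of the method, so compound 2 is the stronger of the measured pair. No single-point comparison between measured compounds is available, and compound 2 differs from compound 1 in more than one place.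

Compound 3 `Cc1ccc(NC(=O)/C=C/C(=O)N2C/C(=C\c3ccccc3)C(=O)/C(=C/c3ccccc3)C2)cc1C` is not yet measured. Relative to compound 1 it carries 3,4-dimethylphenyl in place of phenyl on an amide-type nitrogen. Going by the values given here, with no isolated step of this kind on record, the expectation rests on compound 1 alone: a modest shift toward a lower number, possibly within the scatter, is estimated as a 1.6-fold lower number from compound 1 to compound 3 (0.20 log units; within the scatter). Compound 3 is therefore expected to give about 700 nM, with a plausible range from 250 nM to 2000 nM.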

Compound 3, half-maximal inhibitory concentration: 7100 nM
Beside the measured number, compound 3's estimate is 10-fold (1.01 log units) below it, and the stated range ends below it.
By their numbers in this assay, from the lowest: compound 2; then compound 1; then compound 3.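

In this assay, going by these compounds alone, 3,4-dimethylphenyl in place of phenyl on the amide-type nitrogen gives a 6.5-fold higher number from compound 1 to compound 3 (0.81 log units; beyond the scatter), which is the first change in a single place on record. It shows that this substituent on the amide-type nitrogen is not a silent position: with the core of compound 1 held constant, this change alone makes compound 3 a weaker inhibitor, by a margin beyond the scatter. No measurement on hand accounts for this step.

The compounds shown leave open whether 3-methylphenyl or 4-methylphenyl alone on the same nitrogen would give a step of this size, and whether a methoxy group, a chlorine atom or a carboxylic acid on that phenyl would shift the number either way. They also leave open whether the same change would give a similar step on a core carrying the nitro groups of compound 2.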